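Extending the benzyl substituent toward the biphenyl-like series

The source may hold more compounds than are shown below. What is called first, only, known or untested is meant among the compounds shown, and "the series" means these compounds.

Measured compounds:
- compound 1, `COC(=O)/C=C/c1cccc(N(Cc2ccc(-c3ccc(F)c(F)c3)cc2)C(=O)C2CCCCC2)c1`: 72 nM
- compound 2, `COC(=O)/C=C/c1cccc(N(Cc2ccc(-c3ccc(C(C)(C)C)cc3)cc2)C(=O)C2CCCCC2)c1`: 132 nM
- compound 3, `COC(=O)/C=C/c1cccc(N(Cc2cccc(OC)c2)C(=O)C2CCCCC2)c1`: > 1000 nM

In an assay on isolated protein with Bile acid receptor (Homo sapiens) as the target (on this read-out higher numbers stand for an effect only at larger amounts of compound and lower numbers for an effect already at smaller amounts), compound 1 gives 72 nM and compound 2 gives 132 nM. Within the data shown here, the single measured step, a 1.8-fold higher number from compound 1 to compound 2 (0.26 log units; within the scatter), shows that exchanging one aryl group for another on the outer ring leaves the result within the scatter. For compound 3 the assay reports only a limit, > 1000 nM; this is where compound 3 stands, at the limit described by the limit of > 1000 nM in this assay, at which 1 of the 3 values shown sits, and no number is available for it.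

Compound 4, `COC/C=C/c1ccc(CN(C(=O)C2CCCCC2)c2cccc(/C=C/C(=O)OC)c2)cc1`, differs from compound 3 by 4-(3-methoxyprop-1-en-1-yl)phenyl in place of 3-methoxyphenyl on a saturated chain carbon bound to an amide-type nitrogen. Among the measured compounds shown here, no measured step covers this change directly; the step from compound 1 to compound 2 concerns a different part of the molecule and only says that the outer group can vary without a change beyond the scatter. Compounds 1 and 2 both carry an extended group on the benzyl ring and give numbers, whereas compound 3 with its smaller 3-methoxyphenyl gives only a limit. Compound 4 is therefore expected to give a measurable number, 400 nM, with a range from 100 nM to 2000 nM. For the measured compounds named here, the step of an at least 2.5-fold lower number from compound 3 to compound 4 (0.39 log units; beyond the scatter) is estimated as moving toward lower numbers, though this rests on only three compounds and remains uncertain.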

Compound 4, half-maximal effective concentration: 233 nM
Compound 4: middle estimate off by 1.7-fold (0.23 log units), on the high side, and the stated range covers the measured number.
By their numbers in this assay, from the lowest: compounds 1, 2 and 4 (each within the scatter of the next, the first and the last beyond it). At a limit, above all of these: compound 3.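

With this assay as the measure, an at least 4.2-fold lower number from compound 3 to compound 4 (0.63 log units; beyond the scatter), so the group on the saturated chain carbon bound to an amide-type nitrogen can move the result out of the range where compound 3 sits. Compound 3 has only a limit, not a number: the limit of > 1000 nM in this assay, at which 1 of the 4 values shown sits.

The new compound also shows that a second aromatic ring is not needed for a measurable number: with 3-methoxyprop-1-en-1-yl on the aromatic carbon, there is a 1.8-fold higher number from compound 2 to compound 4 (0.25 log units; within the scatter) and a 3.2-fold higher number from compound 1 to compound 4 (0.51 log units; beyond the scatter), so compound 4 matches one aryl-bearing compound within the scatter but not the other.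

As far as these compounds go, it remains open whether the double bond counts, which a saturated 3-methoxypropyl chain would test. Also open, from the compounds shown here alone, is whether an amine or a carboxylic acid could take the place of the methoxy group.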